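Swapping a ring group at the assay's limit

The source may hold more compounds than are shown below. What is called first, only, known or untested is meant among the compounds shown, and "the series" means these compounds.

In an ADME assay on microsomes from liver (Mus musculus) for metabolic stability (on this read-out lower numbers stand for a shorter-lived compound and higher numbers for a longer-lived compound), compound 1 `CC(C)C(c1ccc(-c2ccc3cccc(F)c3c2)[nH]c1=O)N1CCCCS1(=O)=O` gives 0.0733 h. Compound 2 `CC(C)C(Cc1nnc[nH]1)c1ccc(-c2ccc3cccc(F)c3c2)[nH]c1=O` has no exact number, only a limit of the assay, < 0.0667 h. Its standing therefore rests on (the limit of < 0.0667 h in this assay, at which 1 of the 2 values shown sits).

Compound 3 `Cc1nc(C(c2ccc(-c3ccc4cccc(F)c4c3)[nH]c2=O)C(C)C)[nH]c1C` carries 4,5-dimethyl-1H-imidazol-2-yl in place of (4H-1,2,4-triazol-3-yl)methyl on a saturated chain carbon bound to an aromatic carbon and a saturated chain carbon.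

Within the data shown here, only one measured step bears on this change: an at least 1.0-fold lower number from compound 1 to compound 2 (0.04 log units; that floor lies within the scatter). That step replaced a six-membered non-aromatic ring group with the triazole group at the same place, and it stays within the scatter. It is thin evidence, since it ends on a limit and involves a different pair of groups. Going by compound 2 and that step an at least 1.0-fold lower number from compound 1 to compound 2 (0.04 log units; that floor lies within the scatter), no clear change in either direction is expected in this assay. The expected step is a step that the limit leaves unreadable from compound 2 to compound 3. Compound 3 is estimated at 0.065 h, with an expected range of 0.04 h to 0.15 h. The assay may well report only a limit again.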

Compound 3, half-life: 0.0817 h
Compound 3: middle estimate off by 1.3-fold (0.10 log units), on the low side; low and high end bracket the measured number.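

In this assay, compound 3 gives this place its first exact number for a group with a five-membered aromatic ring, and the step of a 1.1-fold higher number from compound 1 to compound 3 (0.05 log units; within the scatter) shows that 4,5-dimethyl-1H-imidazol-2-yl and the six-membered non-aromatic ring group cannot be told apart on this read-out. The step that removes (4H-1,2,4-triazol-3-yl)methyl is an at least 1.2-fold higher number from compound 2 to compound 3 (0.08 log units; that floor lies within the scatter), so even this exchange of one aromatic ring group for another, with its different chain and ring atoms, does not show a change beyond the scatter. Compound 2 has a limit and not a number, so that step gives only a floor and its true size stays unknown: the limit of < 0.0667 h in this assay, at which 1 of the 3 values shown sits.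

The compounds shown leave open whether any group on this saturated chain carbon can lift the half-life clearly beyond the scatter, since the exact numbers so far do not separate. They also leave open what the two methyl groups contribute, which a plain 1H-imidazol-2-yl group would test, and whether a quite different group, such as a carboxylic acid or an amine, would behave the same way on the shared core.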